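The source may hold more compounds than are shown below. What is called first, only, known or untested is meant among the compounds shown, and "the series" means these compounds.

Measured so far:
Compound 1 `O=[N+]([O-])c1ccc(CN2CCC(n3cc(CC(OCc4cc(-c5cccc(Br)c5)no4)c4ccc(Br)cc4)nn3)CC2)cc1` gives 5000 nM in a functional assay on Caco-2 cells (Homo sapiens) for cytotoxicity, with a stated time of 48 h; on this read-out lower numbers stand for stronger inhibition and higher numbers for weaker inhibition.
Compound 2 `O=[N+]([O-])c1ccc(CN2CCC(n3cc(CC(OCc4cc(-c5ccccc5Br)no4)c4ccc(Br)cc4)nn3)CC2)cc1` gives 3000 nM in this assay.

Within the data shown here, compound 2 has the lowest of the two numbers on this read-out, but its only neighbour, compound 1, lies within the scatter of it: the step of a 1.7-fold lower number from compound 1 to compound 2 (0.22 log units; within the scatter) is too small to be called a change, so the two values are best read as alike.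

Compound 3 `O=[N+]([O-])c1ccc(CN2CCC(n3cc(CC(OCc4cc(-c5ccccc5F)no4)c4ccc(Br)cc4)nn3)CC2)cc1` differs from compound 2 by fluoro in place of bromo on an aromatic carbon. Among the measured compounds shown here, no measured pair shows a swap of one halogen for another at this carbon; the only measured step, from compound 1 to compound 2, moves a bromo group around the ring and stays within the scatter. That step bears only loosely on the present one, and it gives no sign that a halogen exchange at this position shifts the number much.

Compound 3 is therefore expected to land close to compound 2, with an estimated step of a 1.3-fold higher number from compound 2 to compound 3 (0.12 log units; within the scatter), in no particular direction beyond the scatter. The estimate for compound 3 in this assay is 4000 nM, with a likely range from 1500 nM to 12000 nM.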

Compound 3, half-maximal inhibitory concentration: 4000 nM
The estimate for compound 3 equals the measured number at the digits printed; the measured number falls inside the stated range.
By their numbers in this assay, from the lowest: compounds 2, 3 and 1 (each within the scatter of the next).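

In this assay, the step of a 1.3-fold higher number from compound 2 to compound 3 (0.12 log units; within the scatter) gives the first direct view of one halogen exchanged for another on this aromatic carbon, ortho to a large group, and the 2-bromophenyl and 2-fluorophenyl compounds read as alike. The step of a 1.3-fold lower number from compound 1 to compound 3 (0.10 log units; within the scatter) adds that the 3-bromophenyl and 2-fluorophenyl compounds also read as alike, so changing the halogen and its place together leaves no change that can be told from the scatter. Nothing measured alongside these cell values offers a reason for this sameness.

From the compounds shown here alone, all three compounds carry a halogen on this phenyl ring, so it remains open whether a plain hydrogen, a methoxy group, an amine or a carboxylic acid at this carbon would leave the number where it is or move it beyond the scatter. Going by these compounds, it is equally open whether the same indifference to the halogen would hold with another group in place of the bromo on the second phenyl ring of the shared core.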